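The compounds below may be only part of what the source reports. "The series", "measured", "known", "first", "only" and "open" are said of these compounds alone.

Measured so far in an ADME assay on Huh-5-2 cells (Homo sapiens) for cytotoxicity, read by WST assay, with a stated time of 3 days; on this read-out lower numbers stand for higher toxicity in this test and higher numbers for lower toxicity in this test:
compound 1 `O=c1c(OCc2ccccc2[N+](=O)[O-])c(-c2ccccc2)oc2cc(O)cc(O)c12` — 51000 nM
compound 2 `Cc1ccccc1COc1c(-c2ccccc2)oc2cc(O)cc(O)c2c1=O` — 55000 nM
compound 3 `O=c1c(OCc2ccc(Cl)cc2)c(-c2ccccc2)oc2cc(O)cc(O)c12` — 36000 nM

Compound 3 is not set apart from either neighbour: a 1.4-fold lower number from compound 1 to compound 3 (0.15 log units; within the scatter) and a 1.5-fold lower number from compound 2 to compound 3 (0.18 log units; within the scatter), so the three numbers sit together. Compound 4 `COc1ccc(COc2c(-c3ccccc3)oc3cc(O)cc(O)c3c2=O)cc1` takes the step (methoxy in place of chloro on an aromatic carbon). For the measured compounds named here, the steps that bear on it all exchange one substituent on the same ring as this one: a 1.1-fold higher number from compound 1 to compound 2 (0.03 log units; within the scatter), a 1.4-fold lower number from compound 1 to compound 3 (0.15 log units; within the scatter) and a 1.5-fold lower number from compound 2 to compound 3 (0.18 log units; within the scatter). None of them moved the number beyond the scatter, and the same is expected here. For compound 4 the step of a 1.2-fold higher number from compound 3 to compound 4 (0.07 log units; within the scatter) is expected to stay within the scatter. Compound 4 is therefore estimated at 42000 nM, with a range from 20000 nM to 85000 nM.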

Compound 4, half-maximal cytotoxic concentration: 57000 nM
For compound 4 the middle estimate is 1.4-fold (0.13 log units) below the measured one; measured number inside the range.
By their numbers in this assay, from the lowest: compounds 3, 1, 2 and 4 (each within the scatter of the next).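

Methoxy in place of chloro on this aromatic carbon, para to a large group, brings in a hydrogen-bond acceptor, yet in this assay the number does not separate (a 1.6-fold higher number from compound 3 to compound 4 (0.20 log units; within the scatter)). Exchanging the whole aryl group gives the same picture (a 1.0-fold higher number from compound 2 to compound 4 (0.02 log units; within the scatter); a 1.1-fold higher number from compound 1 to compound 4 (0.05 log units; within the scatter)), so all four compounds remain within the scatter of the next. Nothing measured bears on why these numbers stay together. Open, from the compounds shown here alone, is whether an amine, a carboxylic acid or a longer chain in place of methoxy would move the number beyond the scatter.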